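Changing one amide substituent in a clearance series

The source may report more compounds than this note shows. Statements on the series, on what has been measured and on what is new or still open speak of the compounds shown alone.

Values in an in vitro ADME assay on microsomes from liver (Homo sapiens) for pharmacokinetics, read by LC-MS, with a stated time of 10 min, tested at 1 uM (a lower number here means slower removal, a higher number faster removal of the compound), follow

compound 1 `CN1C[C@H](C(=O)Nc2ccc(Br)cc2)[C@@H](c2ccc(/C=C/C(=O)Nc3ccccc3N)cc2)C1` gives 3 mL/min/kg
compound 2 `CN1C[C@H](C(=O)Nc2cccc(Cl)c2)[C@@H](c2ccc(/C=C/C(=O)Nc3ccccc3N)cc2)C1` gives 7 mL/min/kg
compound 3 `Cc1cc(NC(=O)[C@H]2CN(C)C[C@@H]2c2ccc(/C=C/C(=O)Nc3ccccc3N)cc2)ccc1F` gives 15 mL/min/kg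

Compound 3 has the highest number of the three, at 15 mL/min/kg in this assay, and is removed fastest in this small set. The change to compound 4 `Cc1ccc(NC(=O)[C@H]2CN(C)C[C@@H]2c2ccc(/C=C/C(=O)Nc3ccccc3N)cc2)cn1` is 6-methylpyridin-3-yl in place of 4-fluoro-3-methylphenyl on an amide-type nitrogen and puts 6-methylpyridin-3-yl in place of 4-fluoro-3-methylphenyl on an amide-type nitrogen. All three measured steps change the group at this same place. They are a 2.3-fold higher number from compound 1 to compound 2 (0.37 log units; beyond the scatter), a 2.1-fold higher number from compound 2 to compound 3 (0.33 log units; beyond the scatter) and a 5.0-fold higher number from compound 1 to compound 3 (0.70 log units; beyond the scatter), each modest and beyond the scatter. For the measured compounds named here, none of the measured compounds has a ring with a hetero atom here, and the data offer no direct measure of this swap. A lower number is still expected, because compound 2 gave 7 mL/min/kg and compound 1 gave 3 mL/min/kg with other groups at this place. The expected step is a 2.1-fold lower number from compound 3 to compound 4 (0.33 log units; beyond the scatter) and would be similar in size to the measured ones. For compound 4 the estimate is 7 mL/min/kg, with an expected range from 2.5 mL/min/kg to 18 mL/min/kg.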

Compound 4, clearance: 8 mL/min/kg
Beside the measured number, compound 4's estimate is 1.1-fold (0.06 log units) below it; the range from low to high includes it.
By their numbers in this assay, from the lowest: compound 1; then compounds 2, 4 and 3 (each within the scatter of the next, the first and the last beyond it).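

Compound 4 brings the first ring with a hetero atom to this place on an amide-type nitrogen, and in this assay the swap from 4-fluoro-3-methylphenyl to 6-methylpyridin-3-yl gives a 1.9-fold lower number from compound 3 to compound 4 (0.27 log units; within the scatter) and so cannot be told apart from no change at all. The comparison with the 3-chlorophenyl group gives a 1.1-fold higher number from compound 2 to compound 4 (0.06 log units; within the scatter), which places compounds 2, 3 and 4 in a chain of neighbours within the scatter, even though compounds 2 and 3 themselves stand apart, while the 4-bromophenyl group remains separate with a 2.7-fold higher number from compound 1 to compound 4 (0.43 log units; beyond the scatter) and compound 1 keeps the lowest number of the four. Nothing available on these compounds explains why the numbers fall this way.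

With a single ring containing a hetero atom at this place, the compounds shown leave open how much of this result belongs to the ring nitrogen and how much to the methyl group on that ring. As far as these compounds go, it also remains open where an unsubstituted pyridin-3-yl, a pyrimidin-5-yl or a saturated piperidin-4-yl group would fall.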